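Mirror-image pair in an antiproliferative screen

The source may report more compounds than this note shows. Statements on the series, on what has been measured and on what is new or still open speak of the compounds shown alone.

Compound 1 is `C[C@H]1N=C2C[C@H]3C[C@H](C3(C)C)[C@@]2(C)OC1=O`. It was tested in an ADME assay on NIH3T3 cells (Mus musculus) for antiproliferative activity, read by sulforhodamine B assay, with a stated time of 48 h; on this read-out higher numbers stand for weaker inhibition and lower numbers for stronger inhibition. In that test compound 1 reached only a limit of the assay, > 1800000 nM, with no number behind it. Two relatives were measured alongside it. Compound 2, `CC1(C)[C@H]2CC[C@]1(C)[C@H]1OC(=O)CN=C21`, also gave only a limit in this assay, > 900000 nM. Compound 3, `CC1(C)N=C2C[C@H]3C[C@H](C3(C)C)[C@@]2(C)OC1=O`, likewise gave only a limit in this assay, > 2000000 nM. So all three measured values are limits, and compound 1 stands among them with nothing measurable to set it apart; none of the three can be called stronger or weaker than another.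

The step now followed leads to compound 4, `C[C@@H]1N=C2C[C@@H]3C[C@@H](C3(C)C)[C@]2(C)OC1=O`. Its relation to compound 1 is this: the two compounds have the same atoms and bonds and differ only in configuration as drawn: 4 of 4 stereo elements differ (all stereocentres are inverted: mirror images); a stereocentre at a saturated ring carbon is drawn R in compound 1 and S in compound 4; a stereocentre at a saturated ring carbon is drawn R in compound 1 and S in compound 4; a stereocentre at a saturated ring carbon is drawn R in compound 1 and S in compound 4; a stereocentre at a saturated ring carbon is drawn R in compound 1 and S in compound 4. In plain words, compound 4 is the mirror image of compound 1, built from the same atoms and bonds.

Within the data shown here, no measured step compares two mirror images, so nothing here tells whether the mirror form behaves differently. Since compound 1 gave no measurable inhibition at its limit > 1800000 nM, the expectation for compound 4 is that it, too, will most likely sit at a limit rather than give a number. The expected step from compound 1 to compound 4 is therefore a number no higher from compound 1 to compound 4 (the limit leaves the size open), meaning no change beyond the scatter. Compound 4 is expected to give about 1800000 nM in this assay, within a range from 600000 nM to 5000000 nM.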

Compound 4, half-maximal inhibitory concentration: > 2000000 nM
Compound 4 gave a limit, no number; the forecaster's own chance of this, stated with the estimate: 85%; middle value at least 1.1-fold (0.04 log units) away from the limit.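

Compound 4 gave > 2000000 nM as its result, which is only a limit of the assay. Among these compounds, compound 1 also gave only a limit, so no step between compound 1 and compound 4 can be read. Going by these compounds, whether these two mirror images differ at all in antiproliferative activity remains open, as does the concentration either would need to inhibit cell growth.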